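Para Substituent on the Second Aryl Ring in a Triazole Series

This account rests on a few compounds, and the source may have more. Where it says the series, first, only, none or still open, it means among the compounds named here.

Compound 1 `COc1ccccc1-c1ncnn1-c1cc(OC)c(OC)c(OC)c1`: > 10000 nM
Compound 2 `COc1cc(-c2ncnn2-c2ccccc2)cc(OC)c1OC`: > 10000 nM
Compound 3 `COc1ccc(-n2ncnc2-c2cc(OC)c(OC)c(OC)c2)cc1`: 93 nM

In a functional assay on Jurkat cells (Homo sapiens) for antiproliferative activity, read by MTT assay, with a stated time of 72 h (a higher number here means a weaker inhibitor, a lower number a stronger inhibitor), compound 1 gives > 10000 nM, which is a limit of the assay and not a number. Compound 2 likewise gives only a limit, > 10000 nM. For the measured compounds named here, compound 3, with a methoxy in place of hydrogen on an aromatic carbon, gives 93 nM, and the step of an at least 100-fold lower number from compound 2 to compound 3 (2.03 log units; beyond the scatter) is the one measured change that bears here. The values of compound 1 and compound 2 both sit at the limit of > 10000 nM in this assay, at which 2 of the 3 values shown sit. Compound 4 `COc1cc(-n2ncnc2-c2ccc(C)cc2)cc(OC)c1OC` differs from compound 1 by 4-methylphenyl in place of 2-methoxyphenyl on an aromatic carbon. A para group on the second ring carried the large gain in compound 3, so compound 4 is expected to improve by an at least 12-fold lower number from compound 1 to compound 4 (1.09 log units; beyond the scatter). The estimate for compound 4 is 800 nM, with a range from 100 nM to 10000 nM.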

Compound 4, half-maximal inhibitory concentration: 300 nM
Estimate against measurement, compound 4: 2.7-fold (0.43 log units) above; low and high end bracket the measured number.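

On an aromatic carbon between two ring nitrogen atoms, 4-methylphenyl in place of 2-methoxyphenyl gives an at least 33-fold lower number from compound 1 to compound 4 (1.52 log units; beyond the scatter). This shows that the group at this carbon can decide the activity of the shared core in this assay, and that a group without oxygen suffices. The size of the step is only a floor, since compound 1 gives a limit of the assay and not a number: the limit of > 10000 nM in this assay, at which 2 of the 4 values shown sit.

Going by these compounds, it remains open whether the gain comes from losing the methoxy or from the substituent's place on the ring. On these data alone, how an amine or a carboxylic acid would fare in place of the methyl also remains open.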